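Swapping Trifluoromethyl for Phenyl on Two Related Cores

This account rests on a few compounds, and the source may have more. Where it says the series, first, only, none or still open, it means among the compounds named here.

Compound 1 `CN(C)CCC(OC(=O)c1ccc(C(F)(F)F)cc1)c1ccc(Cl)cc1` and compound 2 `CN(C)CCC(OC(=O)c1ccc(-c2ccccc2)cc1)c1ccc(Cl)cc1` share one core and differ in a single place: phenyl in place of trifluoromethyl on an aromatic carbon. In an assay on NIH3T3 cells with Urotensin-2 receptor (Homo sapiens) as the target (on this read-out higher numbers stand for larger maximal responses and lower numbers for smaller maximal responses), compound 1 gives 47%. In this assay compound 2 gives 53%. The change produced a number 6 percentage points higher from compound 1 to compound 2 (within the scatter), so these two values cannot be told apart.

Compound 3 `CN(C)CCC(OC(=O)Nc1ccc(C(F)(F)F)cc1)c1ccc(Cl)cc1` carries the same trifluoromethyl group as compound 1 but on a different core; the difference between the two cores is not broken down here. In this assay compound 3 gives 94%, the highest of the three numbers and beyond the scatter from both compound 1 and compound 2.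

Compound 4 `CN(C)CCC(OC(=O)Nc1ccc(-c2ccccc2)cc1)c1ccc(Cl)cc1` has not yet been measured. It stands to compound 3 as compound 2 stands to compound 1: phenyl in place of trifluoromethyl on an aromatic carbon. The place of this change is described in exactly the same words for both pairs, so it is the same change, now made on the core of compound 3.

Within the data shown here, only one earlier example of the change exists, and it left the maximal response essentially unchanged. The step expected from compound 3 to compound 4 is therefore a number 1 percentage points higher from compound 3 to compound 4 (within the scatter), because the same change earlier made a number 6 percentage points higher from compound 1 to compound 2 (within the scatter). Compound 4 is expected to reach about 95% in this assay. For compound 4 the estimated range runs from 78% to 110%.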

Compound 4, largest response reached (reported as efficacy), in percent of the reference or control that the assay uses: 58%
The estimate for compound 4 lay 37 percentage points above the measured number; measured number outside the range, below it.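

On the core of compound 3, putting phenyl in place of trifluoromethyl produced a number 36 percentage points lower from compound 3 to compound 4 (beyond the scatter) in this assay, so the same change did not have the same outcome on the two cores: the same change on two cores in this assay, a number 6 percentage points higher (within the scatter) from compound 1 to compound 2 and a number 36 percentage points lower (beyond the scatter) from compound 3 to compound 4, 42 percentage points apart, beyond the scatter of two such steps

For these two cores, then, the size of a step measured on one core cannot simply be added to a value on the other, since the result of this swap depends on the core that carries it. Among these compounds, what these numbers do not show is why the two cores part ways, and with only one pair on each core they cannot say how a third core would respond or whether either step would hold in another assay.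

The compounds shown leave open whether the lower response on the core of compound 3 is specific to phenyl, or whether another group in the same place, such as methyl, methoxy or a nitrile, would also lower it. They also leave open whether a group of intermediate size, such as a cyclopropyl group, would give a response closer to that of compound 3 or that of compound 4.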